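Methoxy for Trifluoromethyl on Two Related Cores

The source may report more compounds than this note shows. Statements on the series, on what has been measured and on what is new or still open speak of the compounds shown alone.

Measured compounds:
compound 1, `O=C1C=CCC(/C=C/c2ccc(C(F)(F)F)cc2)O1`, 36.8 uM
compound 2, `COc1ccc(/C=C/C2CC=CC(=O)O2)cc1`, 20.6 uM
compound 3, `O=C1C=CCC(/C=C/c2ccc(C(F)(F)F)cc2)N1`, 130 uM

These values come from a functional assay on U-251 cells (Homo sapiens) for inhibition, read by sulforhodamine B assay, with a stated time of 48 h; a higher number here means a weaker inhibitor of growth, a lower number a stronger inhibitor of growth. Compound 2 differs from compound 1 by methoxy in place of trifluoromethyl on an aromatic carbon, and this gave a 1.8-fold lower number from compound 1 to compound 2 (0.25 log units; within the scatter). Compound 3 shares its side chain with compound 1, but the difference between the two cores is not broken down here; in this assay compound 3 stands highest of the three numbers, beyond the scatter from both others.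

Compound 4, `COc1ccc(/C=C/C2CC=CC(=O)N2)cc1`, is not yet measured. It differs from compound 3 by methoxy in place of trifluoromethyl on an aromatic carbon, the same change as between compound 1 and compound 2, at the same place. Within the data shown here, the step is expected to be a 1.8-fold lower number from compound 3 to compound 4 (0.26 log units; within the scatter), resting on the earlier step because a 1.8-fold lower number from compound 1 to compound 2 (0.25 log units; within the scatter) is the only measured example of this change. Compound 4 is therefore estimated at 72 uM, likely between 35 uM and 150 uM.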

Compound 4, concentration for growth inhibition (reported as GI): 981 uM
Estimate against measurement, compound 4: 14-fold (1.13 log units) below; measured number outside the range, above it.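

In this assay, putting methoxy in place of trifluoromethyl gave a 7.5-fold higher number from compound 3 to compound 4 (0.88 log units; beyond the scatter), so the change did not behave here as it did on the core of compound 1. Among these compounds, the two results lie clearly apart, and a step seen on one core cannot simply be assumed on the other: the same change on two cores in this assay, a 1.8-fold lower number (0.25 log units; within the scatter) from compound 1 to compound 2 and a 7.5-fold higher number (0.88 log units; beyond the scatter) from compound 3 to compound 4, 13-fold (1.13 log units) apart, beyond the scatter of two such steps With only one pair on each core, this shows that the step failed to carry over, but not why the two cores differ or whether other changes would also fail to carry over.

The compounds shown leave open how other groups on this aromatic carbon, such as a chlorine atom, a nitrile or an amine, would behave on each core. They also leave open whether any such group would give matching steps on the two cores.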